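This account rests on a few compounds, and the source may have more. Where it says the series, first, only, none or still open, it means among the compounds named here.

Compound 1 `COc1ccc(/C=C2\CCC/C(=C\c3cccc(OC)c3OC)C2=O)cc1`: 401000 nM
Compound 2 `COc1cccc(/C=C2\CCC/C(=C\c3ccc(F)cc3)C2=O)c1OC`: 33200 nM
Compound 3 `COc1cccc(/C=C2\CCC/C(=C\c3ccc([N+](=O)[O-])cc3)C2=O)c1OC`: < 10000 nM (a limit of the assay)

These values all come from an ADME assay on Vero cells (Chlorocebus sabaeus) for inhibition; on this read-out higher numbers stand for lower toxicity in this test and lower numbers for higher toxicity in this test. For compound 3 the assay reports only a limit, < 10000 nM, and no number. This is the limit of < 10000 nM in this assay, at which 1 of the 3 values shown sits.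

Compound 4 `COc1cccc(/C=C2\CCC/C(=C\c3cccc(Br)c3)C2=O)c1OC` differs from compound 3 by 3-bromophenyl in place of 4-nitrophenyl on a double-bonded chain carbon bound to a double-bonded ring carbon. In words, this places 3-bromophenyl in place of 4-nitrophenyl on a double-bonded chain carbon bound to a double-bonded ring carbon.

Among the compounds with values here, three measured steps bear on this change, since each alters a group on the aromatic ring that is replaced here. Two are large: a 12-fold lower number from compound 1 to compound 2 (1.08 log units; beyond the scatter) and an at least 40-fold lower number from compound 1 to compound 3 (1.60 log units; beyond the scatter). The third is at least modest: an at least 3.3-fold lower number from compound 2 to compound 3 (0.52 log units; beyond the scatter). Within the data shown here, none of the measured compounds carries a 3-bromophenyl group, so the guide is only approximate.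

Compound 4 has a halogen on that ring, as does compound 2 at 33200 nM, so a number near that of compound 2 is expected. A modest rise from the limit is therefore expected, and the expected step is an at least 2.2-fold higher number from compound 3 to compound 4 (0.34 log units; beyond the scatter). The estimated value for compound 4 is 22000 nM, with an expected range from 8000 nM to 70000 nM.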

Compound 4, half-maximal cytotoxic concentration: 31500 nM
Beside the measured number, compound 4's estimate is 1.4-fold (0.16 log units) below it; measured number inside the range.
By their numbers in this assay, from the lowest: compounds 4 and 2 (each within the scatter of the next); then compound 1. At a limit, below all of these: compound 3.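

In this assay, replacing 4-fluorophenyl with 3-bromophenyl on a double-bonded chain carbon bound to a double-bonded ring carbon makes no difference that can be read, with a 1.1-fold lower number from compound 2 to compound 4 (0.02 log units; within the scatter), so a second halogen-bearing ring gives a number that lies with that of compound 2 and stands well apart from the 4-methoxyphenyl compound, with a 13-fold lower number from compound 1 to compound 4 (1.10 log units; beyond the scatter). The change from 4-nitrophenyl also separates the new compound from compound 3, with an at least 3.1-fold higher number from compound 3 to compound 4 (0.49 log units; beyond the scatter), so among the four compounds the two halogen-bearing rings stand between the 4-nitrophenyl and 4-methoxyphenyl rings in this test. Compound 3 stands at a limit, so this last step gives only a minimum size: the limit of < 10000 nM in this assay, at which 1 of the 4 values shown sits.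

The 3-bromophenyl and 4-fluorophenyl groups differ in both the halogen and where it sits on the ring, and the compounds shown leave open whether either difference alone would move the number, as a 4-bromophenyl or 3-fluorophenyl group could show. Also open, going by these compounds, is how the number would respond to an amine or a carboxylic acid on this ring.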